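Replacing Phenyl with Pyridin-4-yl in a Glycine Transporter Series

The source may report more compounds than this note shows. Statements on the series, on what has been measured and on what is new or still open speak of the compounds shown alone.

Compound 1 `O=C(CNC(=O)c1ccc(Cl)cc1)NC(c1ccccc1)c1ccc(Cl)cc1`: 150 nM; 300 nM; 280 nM (3 entries)
Compound 2 `O=C(CNC(=O)c1ccc(F)cc1)NC(c1ccccc1)c1ccccc1`: 110 nM

Both compounds were tested in an assay for inhibition of sodium- and chloride-dependent glycine transporter 1 (Homo sapiens); a higher number here means that more compound is needed for the effect, a lower number that less compound is needed. The repeated measurements of compound 1, (the several entries of compound 1 in this assay, 150 nM; 300 nM; 280 nM (3 entries)), lie within the usual scatter of one another. For the measured compounds named here, compound 2 gives 110 nM in this assay; this is the only number recorded for it, and a further measurement of compound 2 yielded no single number. Going by the values given here, the two compounds differ from each other in two places at once, so no single step connects them; their values simply show that both sit in the same broad region of potency.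

Compound 3 `O=C(CNC(=O)c1ccc(F)cc1)NC(c1ccccc1)c1ccncc1` has not yet been measured. It differs from compound 2 by pyridin-4-yl in place of phenyl on a saturated chain carbon bound to an amide-type nitrogen and an aromatic carbon. Among the compounds with values here, no measured pair in this small set isolates such a change, so any expectation rests on the values of compounds 1 and 2 alone. The expected step of a 2.7-fold higher number from compound 2 to compound 3 (0.44 log units; beyond the scatter) is a modest weakening, towards a higher number, of a size near the edge of the usual scatter. On that basis compound 3 is estimated at 300 nM, with a range from 100 nM to 1000 nM.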

Compound 3, half-maximal effective concentration: 730 nM
Estimate against measurement, compound 3: 2.4-fold (0.39 log units) below, within the range that was stated.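

In this assay, for the compounds shown here, the exchange of phenyl for pyridin-4-yl on the saturated chain carbon gives a 6.6-fold higher number from compound 2 to compound 3 (0.82 log units; beyond the scatter), so this place in the molecule is sensitive to a change that swaps only one ring carbon for a nitrogen and keeps the heavy-atom count the same. The earlier compounds shown here could not show this, since they differ in two places at once and no single change could be read from them. This step is printed as beyond the scatter, and the repeats of one compound give a direct sense of how far values can wander without any change in structure: the several entries of compound 1 in this assay, 150 nM; 300 nM; 280 nM (3 entries).

Still open, going by these compounds, is whether the weakening is tied to a nitrogen at this exact ring position, or would also appear with pyridin-3-yl, pyridin-2-yl or a saturated cyclohexyl ring at the same place. The compounds shown also do not reveal why the number rises, or whether the same exchange would have a similar effect on the chlorine-bearing structure of compound 1.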